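The compounds below may be only part of what the source reports. "The series", "measured", "known", "first", "only" and "open" are said of these compounds alone.

Measured so far in an ADME assay on a cell-free system (plasma, Mus musculus) for metabolic stability, read by LC-MS, tested at 2 uM; on this read-out lower numbers stand for a shorter-lived compound and higher numbers for a longer-lived compound:
- Compound 1 `CC(C)CNC(=O)n1c(=O)oc2ccc(C3CCN(C)CC3)cc21`: 0.5 h
- Compound 2 `CC(C)N1CCC(c2ccc3c(c2)oc(=O)n3C(=O)NCCCCc2ccccc2)CC1`: 0.667 h

Only these two compounds have numbers. Going by the values given here, compound 2 stands within the usual scatter of compound 1, the only other compound measured, so the two values cannot be told apart. The two structures differ in more than one place, and no single change can be read from this pair.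

Compound 3 `CC(=O)N1CCC(c2ccc3c(c2)oc(=O)n3C(=O)NCCCCc2ccccc2)CC1` departs from compound 2 at one point: acetyl in place of isopropyl on an amine nitrogen in a ring. In words, it has acetyl in place of isopropyl on an amine nitrogen in a ring, which turns 1-isopropylpiperidin-4-yl into 1-acetylpiperidin-4-yl. Among the compounds with values here, no measured pair shows what a change at this place does in this assay. Within the data shown here, the only guide is that compound 1 at 0.5 h and compound 2 at 0.667 h lie close together despite their differences. No step beyond the scatter is therefore expected, in either direction. The expected change, a 1.1-fold lower number from compound 2 to compound 3 (0.05 log units; within the scatter), is an estimate that stays within the scatter. For compound 3 the estimated half-life is 0.6 h, with an expected range from 0.3 h to 1.3 h.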

Compound 3, half-life: 0.5 h
The estimate for compound 3 lay 1.2-fold (0.08 log units) above the measured number; the range from low to high includes it.
By their numbers in this assay, from the lowest: compounds 1, 3 and 2 (each within the scatter of the next).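

In this assay, going by these compounds alone, acetyl in place of isopropyl on the amine nitrogen in the ring gives a 1.3-fold lower number from compound 2 to compound 3 (0.13 log units; within the scatter), the first step that can be read at this position, and it stays within the scatter. Acetyl brings a double bond outside aromatic rings and a hydrogen-bond acceptor that isopropyl does not have, yet the half-lives of compound 2 and compound 3 cannot be told apart, so this pair shows no sensitivity to this particular exchange. No measurement at hand bears on the reason for this result.

On these data alone, whether a different kind of group on this nitrogen, such as a sulfonyl group, a bare hydrogen or a chain ending in a carboxylic acid, would give a step beyond the scatter remains open. Compound 1 differs from compound 2 in more than one place, so the effect of the rest of the structure on the half-life also remains unread.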